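This account rests on a few compounds, and the source may have more. Where it says the series, first, only, none or still open, it means among the compounds named here.

Two compounds of the series carry the same core with an aryloxy substituent on the pendant phenyl ring. Compound 1 `O=c1cc1-c1ccc(Oc2ccccc2)cc1` gives 730 nM in an assay on isolated protein for inhibition of glutathione S-transferase P (Homo sapiens); a lower number here means a stronger inhibitor, a higher number a weaker inhibitor. For the measured compounds named here, compound 2 `O=c1cc1-c1ccc(OCc2ccc(-c3ccccc3)cc2)cc1` gives 3200 nM in the same assay, which is the higher of the two numbers measured so far, and the gap to compound 1 lies beyond the usual scatter, so compound 2 is the weaker of the two on the numbers available.

Compound 3 `O=c1cc1-c1ccc(OCc2ccccc2)cc1` has not yet been measured. It differs from compound 2 in a single place: hydrogen in place of phenyl on an aromatic carbon. The terminal phenyl of compound 2 is removed while the benzyloxy linkage is kept.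

Going by the values given here, no step between measured compounds speaks directly to this change. Compound 1, without the extra ring and without the methylene, gives the lower number, so a modest decrease from compound 2 is expected, close to or only slightly beyond the scatter. The expected step from compound 2 to compound 3 is a 1.8-fold lower number from compound 2 to compound 3 (0.25 log units; within the scatter). Compound 3 is therefore estimated at 1800 nM, with a range from 600 nM to 5000 nM.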

Compound 3, half-maximal inhibitory concentration: 730 nM
Beside the measured number, compound 3's estimate is 2.5-fold (0.39 log units) above it; measured number inside the range.
By their numbers in this assay, from the lowest: compounds 1 and 3 (each within the scatter of the next); then compound 2.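

For the compounds shown here, putting hydrogen in place of phenyl on this aromatic carbon gives a 4.4-fold lower number from compound 2 to compound 3 (0.64 log units; beyond the scatter) in this assay, the first single-place step, and it shows that the terminal phenyl is not required for a number in the range seen here. The benzyloxy linkage alone does not carry the higher number of compound 2: compound 3 keeps that linkage and gives 730 nM, and compound 1, which has no methylene, gives 730 nM. Nothing available explains why the phenyl goes with the higher number.

Whether a methyl, a methoxy or a carboxylic acid on this aromatic carbon would read closer to compound 3 or to compound 2 remains open, as the compounds shown offer only hydrogen and phenyl there. Also open, going by these compounds, is how a longer chain in place of the benzyloxy linkage would read on the shared core, and whether any substituent on the terminal ring of compound 3 would move the number at all.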